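A few compounds are considered here, and "the series" means these few. Any claim that something is new, unique, unknown or untested is made for them only; others in the source may bear on it.

Measured compounds:
- compound 1, `O=S(=O)(c1ccccc1)c1nc2ccccc2nc1Nc1ccccc1`, 590 nM in a functional assay on PC-3 cells (Homo sapiens) for cytotoxicity, read by MTT assay, with a stated time of 72 h; a higher number here means a weaker inhibitor, a lower number a stronger inhibitor
- compound 2, `COc1cc(Nc2nc3ccccc3nc2S(=O)(=O)c2ccccc2)cc(OC)c1`, 140 nM
- compound 3, `O=S(=O)(c1ccccc1)c1nc2ccccc2nc1Nc1ccc(Cl)cc1`, 15300 nM

Among these three, compound 1 stands second highest: compound 2 sits below it, as a 4.2-fold lower number from compound 1 to compound 2 (0.62 log units; beyond the scatter) shows, and compound 3 sits far above it, as a 26-fold higher number from compound 1 to compound 3 (1.41 log units; beyond the scatter) shows. Both of those changes were made on the ring attached to the nitrogen of the shared core, and both moved the number well beyond the scatter, with a 110-fold higher number from compound 2 to compound 3 (2.04 log units; beyond the scatter) the widest gap seen.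

Compound 4, `Cc1ccc(S(=O)(=O)c2nc3ccccc3nc2Nc2ccccc2)cc1`, differs from compound 1 elsewhere: methyl in place of hydrogen on an aromatic carbon, on the ring attached to the sulfonyl group. Among the compounds with values here, no measured step touches that ring, so none of the three steps bears directly on this change. The measured data only show that the other ring is sensitive; they say nothing about this one. Lacking a comparable step, the expectation is a small change, not clearly beyond the scatter, so a 1.0-fold higher number from compound 1 to compound 4 (0.01 log units; within the scatter) is estimated as close to none. Compound 4 is therefore expected to give about 600 nM, within 150 nM to 2500 nM.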

Compound 4, half-maximal inhibitory concentration: 1060 nM
Compound 4: the middle estimate sits 1.8-fold (0.25 log units) below what was measured; measured number inside the range.
By their numbers in this assay, from the lowest: compound 2; then compounds 1 and 4 (each within the scatter of the next); then compound 3.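

This is the only view of the ring attached to the sulfonyl group among these compounds. In this assay, methyl in place of hydrogen, para to a large group, gives a 1.8-fold higher number from compound 1 to compound 4 (0.25 log units; within the scatter) and so cannot be told apart from no change, which means this position accepts one added methyl with no clear loss, unlike the ring on the nitrogen, where chloro in place of hydrogen gives a 26-fold higher number from compound 1 to compound 3 (1.41 log units; beyond the scatter) on the same shared core. No measurement here accounts for either result.

On these data alone, a single methyl says little about this position as a whole, so the effect of a different group there, such as an amine, a carboxylic acid or a longer chain, remains open. Also open, as far as these compounds go, is whether the methyl would behave the same way alongside the 3,5-dimethoxyphenyl group of compound 2.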